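Amide to Urea Swap on a Pyrazole Scaffold

The source may hold more compounds than are shown below. What is called first, only, known or untested is meant among the compounds shown, and "the series" means these compounds.

Measured so far:
compound 1 `O=C(Nc1cccc(-n2cc(-c3ccncc3)c(-c3ccc(Cl)c(O)c3)n2)c1)Nc1ccc(Cl)c(Cl)c1` — > 32500 nM
compound 2 `COc1cc(-c2nn(-c3cccc(NC(=O)c4cccc(C(F)(F)F)c4)c3)cc2-c2ccncc2)ccc1Cl` — > 50000 nM
compound 3 `O=C(Nc1cccc(-n2cc(-c3ccncc3)c(-c3ccc(Cl)c(O)c3)n2)c1)Nc1cc(C(F)(F)F)cc(C(F)(F)F)c1` — 3810 nM

These three compounds were tested in a functional assay on SK-OV-3 cells (Homo sapiens) for inhibition, read by sulforhodamine B assay, with a stated time of 48 h; on this read-out lower numbers stand for stronger inhibition of growth and higher numbers for weaker inhibition of growth. Compound 2 gives only a limit, (the limit of > 50000 nM in this assay, at which 1 of the 3 values shown sits), so no number for it is known. Compound 1 likewise gives only a limit, (the limit of > 32500 nM in this assay, at which 1 of the 3 values shown sits). Within the data shown here, compound 3 is the one compound of the three with a measured value, 3810 nM. Among the measured compounds shown here, compounds 1 and 3 differ from compound 2 in more than one place, so no single step between measured compounds can be followed here.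

The unmeasured compound 4 `COc1cc(-c2nn(-c3cccc(NC(=O)Nc4ccc(Cl)c(C(F)(F)F)c4)c3)cc2-c2ccncc2)ccc1Cl` arises from compound 2 by one change: (4-chloro-3-(trifluoromethyl)phenyl)amino in place of 3-(trifluoromethyl)phenyl on a carbonyl carbon.

With compound 2 standing only at a limit, the step to compound 4 cannot be sized from data; the expectation is that compound 4 moves into the measurable range, giving a step of an at least 3.3-fold lower number from compound 2 to compound 4 (0.52 log units; beyond the scatter) in this assay. Compound 4 is therefore expected to give roughly 15000 nM in this assay, with the estimate spanning 4000 nM to 50000 nM, and a real chance remains that only a limit is reported again.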

Compound 4, concentration for total growth inhibition: 13000 nM
Beside the measured number, compound 4's estimate is 1.2-fold (0.06 log units) above it; measured number inside the range.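

In this assay, among these compounds, placing (4-chloro-3-(trifluoromethyl)phenyl)amino in place of 3-(trifluoromethyl)phenyl on a carbonyl carbon gives an at least 3.8-fold lower number from compound 2 to compound 4 (0.58 log units; beyond the scatter), the first step that can be read at all and one that lies beyond the scatter. This single step brings two changes together: the amide becomes a urea, adding a nitrogen with one hydrogen-bond donor, and the aromatic ring gains a chlorine, so the gain in growth inhibition belongs to the combined change and not to either part alone. Compound 2 gives a limit and not a number, so the step has only a lower bound and its full size remains unknown: the limit of > 50000 nM in this assay, at which 1 of the 4 values shown sits.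

The compounds shown leave open whether the urea link or the chlorine matters more, a question that a urea carrying 3-(trifluoromethyl)phenyl or an amide carrying 4-chloro-3-(trifluoromethyl)phenyl could help settle. They also leave open how this urea would respond if a nitrile or a dimethylamino group took the place of the chlorine.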